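Cutting the Side Chain Back on a Weak Inhibitor

The source may hold more compounds than are shown below. What is called first, only, known or untested is meant among the compounds shown, and "the series" means these compounds.

Compound 1 `CCc1nnc(O)n2c(C(C)CC)nc(C)c12` was tested in a functional assay for inhibition, with Homo sapiens as the target (a higher number here means a weaker inhibitor, a lower number a stronger inhibitor), where compound 1 gives 45000 nM. Among the compounds with values here, that is the only number among the two values shown. Compound 2 `CNc1nncc2cncn12` returns only a limit in this assay, > 48000 nM, and not a number. The values in this assay run down to the limit of > 48000 nM in this assay, at which 1 of the 2 values shown sits. Within the data shown here, compound 1 thus stands as the one compound with a measured value, and that value places it among weak inhibitors in this assay.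

Compound 3 `CCc1nnc(O)n2c(CC)nc(C)c12` differs from compound 1 in one place: hydrogen in place of ethyl on a saturated chain carbon bound to an aromatic carbon and a saturated chain carbon. Among the measured compounds shown here, no step between two measured compounds is available, so the size of this change cannot be read from a pair already in hand. Shortening the chain at the saturated chain carbon is expected to move this assay by little, and the step from compound 1 to compound 3 is expected to be a 1.3-fold higher number from compound 1 to compound 3 (0.12 log units; within the scatter), within or barely beyond the scatter, with no clear direction. Compound 3 is therefore estimated at 60000 nM, with a range from 20000 nM to 150000 nM, and a real chance that this assay reports only a limit for it.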

Compound 3, half-maximal inhibitory concentration: 24000 nM
Estimate against measurement, compound 3: 2.5-fold (0.40 log units) above; the range from low to high includes it.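

Going from sec-butyl to ethyl gives a 1.9-fold lower number from compound 1 to compound 3 (0.27 log units; within the scatter) and so, in this assay, this change yields no difference that can be told from the scatter. This first reading at this place shows that the ethyl on the saturated chain carbon bound to an aromatic carbon and a saturated chain carbon can go while compound 3 still returns a number and not a limit, so the longer, branched chain of compound 1 is not needed for the weak inhibition seen here. Compound 2, which differs from these two in more than one place, returns a limit and not a number: the limit of > 48000 nM in this assay, at which 1 of the 3 values shown sits.

Within the data shown here, with only this one step, and both compounds still weak inhibitors, it remains open whether this place can shift this assay by more than the scatter at all. What a methyl, a phenyl ring, an amine or a carboxylic acid at this carbon would do is also unsettled, as is whether any change elsewhere on the shared core would give a clearly lower number.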